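This account rests on a few compounds, and the source may have more. Where it says the series, first, only, none or still open, it means among the compounds named here.

Three compounds share one core: compound 1 is `Fc1cccc(F)c1Cc1cnc(Nc2ccc(Oc3cccnc3)cc2)o1`, compound 2 is `Fc1cccc(F)c1Cc1cnc(Nc2ccc(Oc3ccncc3)cc2)o1` and compound 3 is `OCc1ccc(Nc2ncc(Cc3c(F)cccc3F)o2)cc1`. In an ADME assay on MT2 cells (Homo sapiens) for cytotoxicity, read by MTT assay (a lower number here means that less compound is tolerated, a higher number that more compound is tolerated), compound 1 gives 22000 nM and compound 2 gives 21000 nM, and the step of a 1.0-fold lower number from compound 1 to compound 2 (0.02 log units; within the scatter). Compound 3 reaches only the limit of this assay, > 100000 nM, so for compound 3 a limit rather than a number stands (the limit of > 100000 nM in this assay, at which 1 of the 3 values shown sits). Compound 4, `Fc1cccc(F)c1Cc1cnc(Nc2ccc(CCOc3ccncc3)cc2)o1`, differs from compound 3 by ((pyridin-4-yl)oxy)methyl in place of hydroxy on a saturated chain carbon bound to an aromatic carbon, which cut one bond further out reads hydroxymethyl to 2-((pyridin-4-yl)oxy)ethyl. The steps of an at least 4.5-fold higher number from compound 1 to compound 3 (0.65 log units; beyond the scatter) and an at least 4.7-fold higher number from compound 2 to compound 3 (0.67 log units; beyond the scatter) bear on this change in reverse, since compound 4 carries a (pyridin-4-yl)oxy group again, so a fall beyond the scatter is expected, an at least 3.3-fold lower number from compound 3 to compound 4 (0.52 log units; beyond the scatter). Compound 4 is estimated at 30000 nM, between 12000 nM and 100000 nM.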

Compound 4, half-maximal cytotoxic concentration: 11000 nM
Estimate against measurement, compound 4: 2.7-fold (0.44 log units) above; the whole stated range lies above it.
By their numbers in this assay, from the lowest: compounds 4, 2 and 1 (each within the scatter of the next). At a limit, above all of these: compound 3.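

Compound 3 stands at a limit, not a number: the limit of > 100000 nM in this assay, at which 1 of the 4 values shown sits.

In this assay, 2-((pyridin-4-yl)oxy)ethyl in place of hydroxymethyl gives an at least 9.0-fold lower number from compound 3 to compound 4 (0.95 log units; beyond the scatter), so the fall seen with the directly attached pyridine-bearing groups also appears with this longer chain. Set against those groups, the chain makes no change beyond the scatter: a 1.9-fold lower number from compound 2 to compound 4 (0.28 log units; within the scatter) and a 2.0-fold lower number from compound 1 to compound 4 (0.30 log units; within the scatter).

On these data alone, it remains open whether a phenyl ring on the same chain, or an amine or carboxylic acid in place of the hydroxy, would behave like compound 3 or compound 4.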